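The source may hold more compounds than are shown below. What is called first, only, known or untested is meant among the compounds shown, and "the series" means these compounds.

Of the compounds shown here, two so far give numbers in a functional assay on MCF7 cells (Homo sapiens) for antiproliferative activity, with a stated time of 48 h; a lower number here means a stronger inhibitor, a higher number a weaker inhibitor. Compound 1 `CC(C)(C)c1ccc(NC(=O)CCl)cc1` gives 5400 nM. Compound 2 `O=C(CCCl)Nc1ccc(I)cc1` gives 26000 nM, the highest of the two numbers, which lies beyond the scatter above compound 1. Going by the values given here, these two differ in more than one place, so what their two values show is only that compound 2 is the weaker inhibitor of the pair.

Compound 3 `CC(C)(C)c1ccc(NC(=O)CCCl)cc1` has not yet been measured in this assay. Compared with compound 2, it carries tert-butyl in place of iodo on an aromatic carbon, and the rest of the molecule, including the chain on the amide, is unchanged. Among the compounds with values here, no single-change step between measured compounds covers this exchange, so its size is not known from the data. Within the data shown here, compound 1, the only other compound, carries the same tert-butyl group and gives a lower number, 5400 nM, but it also has a shorter chain, so it is only a rough pointer.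

From that pointer, the step from compound 2 to compound 3 is expected to lower the number by a 2.6-fold lower number from compound 2 to compound 3 (0.41 log units; beyond the scatter). Compound 3 is therefore estimated at 10000 nM, with a range from 3000 nM to 35000 nM.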

Compound 3, half-maximal inhibitory concentration: 49000 nM
Estimate against measurement, compound 3: 4.9-fold (0.69 log units) below, outside the stated range (above it).
By their numbers in this assay, from the lowest: compound 1; then compounds 2 and 3 (each within the scatter of the next).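

In this assay, tert-butyl in place of iodo on an aromatic carbon gives a 1.9-fold higher number from compound 2 to compound 3 (0.28 log units; within the scatter), so at this position, para to a group of 6 heavy atoms, the assay does not separate these two groups on the longer chain, even though tert-butyl brings more heavy atoms than iodo. With tert-butyl held fixed, chloromethyl in place of chloro on the saturated chain carbon bound to a carbonyl carbon gives a 9.1-fold higher number from compound 1 to compound 3 (0.96 log units; beyond the scatter), so among these compounds the chain change, and not the aromatic group change, is the one step that lies beyond the scatter, and compound 1 stays the only clear leader of the three. No measurement available here offers an explanation for either step.

The compounds shown leave open whether the shorter chain of compound 1 would bring the same drop in the number when iodo sits on the aromatic ring. They also leave open how a longer chain, or an amine in place of the chloro group on the chain, would read in this assay.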